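Nitro to vinyl at a cytotoxicity limit

The source may report more compounds than this note shows. Statements on the series, on what has been measured and on what is new or still open speak of the compounds shown alone.

Of the compounds shown here, three sharing one core have been read in an ADME assay on HepG2 2.2.15 cells (Homo sapiens) for cytotoxicity, read by neutral red uptake, with a stated time of 24 h; a higher number here means a weaker inhibitor, a lower number a stronger inhibitor: compound 1 `Nc1ncnc2c1c(Cl)cn2[C@@H]1C=C(CO)[C@@H](O)[C@H]1O`, compound 2 `Nc1ncnc2c1c(I)cn2[C@@H]1C=C(CO)[C@@H](O)[C@H]1O` and compound 3 `Nc1ncnc2c1c([N+](=O)[O-])cn2[C@@H]1C=C(CO)[C@@H](O)[C@H]1O`. Compound 1 gives > 300000 nM, which is a limit and not a number. Compound 2 gives > 300000 nM, also a limit. Compound 3 gives > 300000 nM, again a limit. Compound 3 therefore has no exact place, and all the readings sit together at the limit of > 300000 nM in this assay, at which 3 of the 3 values shown sit.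

Compound 4 `C=Cc1cn([C@@H]2C=C(CO)[C@@H](O)[C@H]2O)c2ncnc(N)c12` carries vinyl in place of nitro on an aromatic carbon. The closest guides are the earlier exchanges at that same place, a step that the two limits leave unreadable from compound 1 to compound 2, a step that the two limits leave unreadable from compound 1 to compound 3 and a step that the two limits leave unreadable from compound 2 to compound 3. None of them has a size that can be read, and none left the limit of this assay. Resting on a step that the two limits leave unreadable from compound 1 to compound 3 and a step that the two limits leave unreadable from compound 2 to compound 3, the estimated step of a number no higher from compound 3 to compound 4 (the limit leaves the size open) has no expected direction and no expected size beyond the scatter. Compound 4 is expected near 300000 nM, within an estimated range of 150000 nM to 600000 nM.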

Compound 4, half-maximal inhibitory concentration: > 300000 nM
Compound 4 gave a limit, no number; the forecaster's own chance of this, stated with the estimate: 80%; the middle value lies on the limit itself.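

Compound 4 sits at the same limit as compound 1, compound 2 and compound 3, so no step between compound 4 and any of them can be read: the limit of > 300000 nM in this assay, at which 4 of the 4 values shown sit.

Whether the group at this place matters at all, and what exact value any of these compounds has, stays open in this assay.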